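Chloro in place of hydroxy on the core of compound 2

This account rests on a few compounds, and the source may have more. Where it says the series, first, only, none or still open, it means among the compounds named here.

Three compounds built on a shared core have been examined in a functional assay on P388 cells (Mus musculus) for cytotoxicity; on this read-out lower numbers stand for an effect already at smaller amounts and higher numbers for an effect only at larger amounts of compound. Compound 1 `Oc1cc(-c2ccccc2)nc2c(O)cccc12` reaches only a limit of the assay, recorded as > 10 ug/mL (the limit of > 10 ug/mL in this assay, at which 1 of the 3 values shown sits). Compound 2 `Oc1ccc2nc(-c3ccccc3)cc(O)c2c1` gives 2.86 ug/mL in this assay. Compound 3 `CCOc1cc(-c2ccccc2)nc2ccccc12` gives 6 ug/mL in this assay. Of the two numbers shown, compound 2 stands lowest, and its gap to compound 3 lies beyond the usual scatter of repeated measurements.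

Compound 4 `Oc1cc(-c2ccccc2)nc2ccc(Cl)cc12` has not yet been measured. It differs from compound 2 in one place: chloro in place of hydroxy on an aromatic carbon. Within the data shown here, no pair of measured compounds differs in a single place, so no measured step can guide the size of this change. Among the measured compounds shown here, compound 2 carries the lowest number so far, and on that footing compound 4 is expected to give about 3 ug/mL in this assay, within a range from 1 ug/mL to 10 ug/mL. The step this estimate implies is a 1.0-fold higher number from compound 2 to compound 4 (0.02 log units; within the scatter), expected to stay within the scatter.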

Compound 4, half-maximal effective concentration: 0.84 ug/mL
Compound 4: the middle estimate sits 3.6-fold (0.55 log units) above what was measured; measured number below the stated range.
By their numbers in this assay, from the lowest: compound 4; then compound 2; then compound 3. At a limit, above all of these: compound 1.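

In this assay, among these compounds, chloro in place of hydroxy gives the first single-place comparison on the shared core, a 3.4-fold lower number from compound 2 to compound 4 (0.53 log units; beyond the scatter). The hydroxy is therefore not needed at this position, on an aromatic carbon meta to a fused ring and para to a fused ring, for a low number on this read-out: a hydrogen-bond donor and acceptor leave with it, and none enter with the chloro. Nothing measured here bears on why the number falls with this change.

The compounds shown leave open whether the step follows from the presence of chloro or from the absence of hydroxy, as no plain hydrogen at this position can be compared. On these data alone, how a bromo, a methoxy or an amine would read at the same position also remains open.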